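Inverting the stereocentre in the thioamide series

A few compounds are considered here, and "the series" means these few. Any claim that something is new, unique, unknown or untested is made for them only; others in the source may bear on it.

Measured compounds:
compound 1 `C[C@@H](NC(=O)OC(C)(C)C)c1nc(-c2nc(-c3nc(C(N)=O)cs3)cs2)cs1` gives 22400 nM
compound 2 `C[C@H](NC(=O)OC(C)(C)C)c1nc(-c2nc(-c3nc(C(N)=O)cs3)cs2)cs1` gives 7600 nM
compound 3 `C[C@@H](NC(=O)OC(C)(C)C)c1nc(-c2nc(-c3nc(C(N)=S)cs3)cs2)cs1` gives 45200 nM

In a functional assay on HCT-116 cells (Homo sapiens) for inhibition, read by CCK-8 assay (a lower number here means a stronger inhibitor, a higher number a weaker inhibitor), compound 3 stands with the highest number of the three, nearest to compound 1 and furthest from compound 2, and the step of a 2.0-fold higher number from compound 1 to compound 3 (0.30 log units; within the scatter) lies within the scatter. Compound 4 `C[C@H](NC(=O)OC(C)(C)C)c1nc(-c2nc(-c3nc(C(N)=S)cs3)cs2)cs1` has not been measured; (the two compounds have the same atoms and bonds and differ only in configuration as drawn: 1 of 1 stereo elements differ; a stereocentre at a saturated chain carbon is drawn R in compound 3 and S in compound 4). Among the measured compounds shown here, the one measured step bearing on this is a 2.9-fold lower number from compound 1 to compound 2 (0.47 log units; beyond the scatter), and the fact that compounds 1 and 2 differ only in the configuration as drawn shows that it is the same inversion. Compound 4 is therefore expected to show a 3.0-fold lower number from compound 3 to compound 4 (0.48 log units; beyond the scatter) in this assay, a modest drop. Compound 4 is estimated at 15000 nM, between 6000 nM and 40000 nM.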

Compound 4, half-maximal inhibitory concentration: 38100 nM
For compound 4 the middle estimate is 2.5-fold (0.40 log units) below the measured one; the measured number falls inside the stated range.
By their numbers in this assay, from the lowest: compound 2; then compounds 1, 4 and 3 (each within the scatter of the next).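

In this assay, the inversion with the thioamide in place gives a 1.2-fold lower number from compound 3 to compound 4 (0.07 log units; within the scatter), so the effect of configuration seen with the carboxamide does not appear in this pair. Among the compounds shown here, on the stereocentre drawn S, the thioamide in place of the carboxamide gives a 5.0-fold higher number from compound 2 to compound 4 (0.70 log units; beyond the scatter), the first step for this exchange beyond the scatter. Even so, the exchange cannot be said to depend on configuration: the same change on two cores in this assay, a 2.0-fold higher number (0.30 log units; within the scatter) from compound 1 to compound 3 and a 5.0-fold higher number (0.70 log units; beyond the scatter) from compound 2 to compound 4, 2.5-fold (0.40 log units) apart, within the scatter of two such steps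

The compounds shown leave open how a carboxylic acid or a nitrile on that aromatic carbon would read in this assay on either configuration.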